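Aryl replacement of bromo in an antiproliferative amide series

A few compounds are considered here, and "the series" means these few. Any claim that something is new, unique, unknown or untested is made for them only; others in the source may bear on it.

- compound 1 `O=C(CCc1cccc2c1B(O)OC2)Nc1cccc(Br)c1` at 540 nM
- compound 2 `O=C(CCc1cccc2c1B(O)OC2)Nc1cccc(-c2ccccc2)c1` at 250 nM
- compound 3 `CSc1cccc(-c2cccc(NC(=O)CCc3cccc4c3B(O)OC4)c2)c1` at 150 nM

Compound 3 stands at the low end of the three values in a functional assay on SK-OV-3 cells (Homo sapiens) for antiproliferative activity, read by MTT assay, with a stated time of 72 h (a lower number here means a stronger inhibitor, a higher number a weaker inhibitor), and level, within the scatter, with its nearest neighbour. The nearest step is a 1.7-fold lower number from compound 2 to compound 3 (0.22 log units; within the scatter) and the widest is a 3.6-fold lower number from compound 1 to compound 3 (0.56 log units; beyond the scatter) in this set.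

Compound 4 `N#Cc1ccc(-c2cccc(NC(=O)CCc3cccc4c3B(O)OC4)c2)cc1` comes next, with 4-cyanophenyl in place of 3-(methylsulfanyl)phenyl on an aromatic carbon as its change. Replacing bromo with phenyl gave a 2.2-fold lower number from compound 1 to compound 2 (0.33 log units; beyond the scatter) as a modest shift, while adding methylsulfanyl to that phenyl gave only a 1.7-fold lower number from compound 2 to compound 3 (0.22 log units; within the scatter) as its effect. Among the measured compounds shown here, no measured compound carries a nitrile, so neither step speaks to this group directly. The phenyl stays and only its substituent changes, so no step beyond the scatter is expected. The expected move is a 1.3-fold higher number from compound 3 to compound 4 (0.10 log units; within the scatter) in this assay on present evidence. For compound 4 the estimate is 190 nM with an expected range from 85 nM to 430 nM in this series.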

Compound 4, half-maximal inhibitory concentration: 340 nM
Estimate against measurement, compound 4: 1.8-fold (0.25 log units) below, and the stated range covers the measured number.
By their numbers in this assay, from the lowest: compounds 3, 2, 4 and 1 (each within the scatter of the next, the first and the last beyond it).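

In this assay, among the compounds shown here, the group carried on the phenyl at this position can move the number: 4-cyanophenyl in place of 3-(methylsulfanyl)phenyl gives a 2.3-fold higher number from compound 3 to compound 4 (0.36 log units; beyond the scatter) here, the first step beyond the scatter in which a phenyl stays in place. Cyano in place of hydrogen gives a 1.4-fold higher number from compound 2 to compound 4 (0.13 log units; within the scatter) and 4-cyanophenyl in place of bromo gives a 1.6-fold lower number from compound 1 to compound 4 (0.20 log units; within the scatter) in this series, so compound 4 sits within the scatter of both compound 2 and compound 1, although those two are printed as beyond the scatter of each other. Nothing available explains the step from the methylsulfanyl to the cyano compound.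

The two substituted phenyls differ both in the group and in where it stands, and the compounds shown do not separate the two. From the compounds shown here alone, whether an amine or a carboxylic acid on this phenyl would fall nearer compound 3 or compound 4 remains open.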